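Aminomethyl in Place of Amino: Estimating Compound 4

A few compounds are considered here, and "the series" means these few. Any claim that something is new, unique, unknown or untested is made for them only; others in the source may bear on it.

Measured so far:
compound 1, `COc1ccnc(-c2cc(Cl)ccc2NS(=O)(=O)c2ccc(C(C)(C)C)cc2)c1`, gives 2500 nM
compound 2, `CC(C)(C)c1ccc(S(=O)(=O)Nc2ccc(Cl)cc2-c2ncccc2N)cc1`, gives 95 nM
compound 3, `CC(C)(C)c1ccc(S(=O)(=O)Nc2ccc(Cl)cc2-c2ncccc2CO)cc1`, gives 89 nM

In a functional assay on isolated protein for antagonist activity at C-C chemokine receptor type 9 (Homo sapiens), read by calcium flux, with a stated time of 10 min (on this read-out lower numbers stand for stronger inhibition and higher numbers for weaker inhibition), compound 2 stands second highest of the three numbers. Its nearest neighbour is compound 3, separated by a 1.1-fold lower number from compound 2 to compound 3 (0.03 log units; within the scatter); its furthest is compound 1, separated by a 26-fold lower number from compound 1 to compound 2 (1.42 log units; beyond the scatter). The third measured step, a 28-fold lower number from compound 1 to compound 3 (1.45 log units; beyond the scatter), runs from compound 1 as well.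

The unmeasured compound 4, `CC(C)(C)c1ccc(S(=O)(=O)Nc2ccc(Cl)cc2-c2ncccc2CN)cc1`, differs from compound 2 by aminomethyl in place of amino on an aromatic carbon. Going by the values given here, of the three measured steps, only the one from compound 2 to compound 3 bears directly on this change: it exchanges the same amino group on the same aromatic carbon for another small uncharged group and stays within the scatter. The two steps from compound 1 replace the whole pyridinyl group and so describe the gap to compound 1 rather than this substituent. The expectation is therefore a step of no more than the scatter, a 1.1-fold higher number from compound 2 to compound 4 (0.02 log units; within the scatter). Compound 4 is accordingly estimated at 100 nM, with a range from 40 nM to 250 nM.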

Compound 4, half-maximal inhibitory concentration: 3160 nM
Estimate against measurement, compound 4: 32-fold (1.50 log units) below, outside the stated range (above it).
By their numbers in this assay, from the lowest: compounds 3 and 2 (each within the scatter of the next); then compounds 1 and 4 (each within the scatter of the next).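

In this assay, this aromatic carbon proves far more selective than compound 2 and compound 3 suggested, since aminomethyl in place of amino brings a 33-fold higher number from compound 2 to compound 4 (1.52 log units; beyond the scatter) and not a change within the scatter. The end of the chain matters as well: with the saturated chain carbon kept, amino in place of hydroxy gives a 36-fold higher number from compound 3 to compound 4 (1.55 log units; beyond the scatter), so hydroxymethyl and aminomethyl are not interchangeable here. With a 1.3-fold higher number from compound 1 to compound 4 (0.10 log units; within the scatter), the large difference that set compound 2 and compound 3 apart from compound 1 does not appear for compound 4.

No measurement offered here explains this loss. On these data alone, it remains open whether methoxymethyl, dimethylaminomethyl, a carboxylic acid or a longer chain such as 2-aminoethyl on this carbon would behave like hydroxymethyl or like aminomethyl.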